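Replacing the Chain End of Compound 1

The source may report more compounds than this note shows. Statements on the series, on what has been measured and on what is new or still open speak of the compounds shown alone.

In a functional assay on A549 cells (Homo sapiens) for antiproliferative activity, read by MTT assay, with a stated time of 48 h (on this read-out lower numbers stand for stronger inhibition of growth and higher numbers for weaker inhibition of growth), compound 1 (`CCOc1cc(NC(=O)CCCCCCC(=O)Nc2ccccc2N)cc2c1OCC([N+](=O)[O-])=C2`) gives 11700 nM. For the measured compounds named here, compound 2 (`CCOc1cc(NC(=O)CCCCCCC(=O)Nc2cc(-c3ccc(C)s3)ccc2N)cc2c1OCC([N+](=O)[O-])=C2`) gives 5830 nM, so the two values lie within the usual scatter of each other, and compound 1 has no clear rank against its only measured neighbour.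

Compound 3 (`CCOc1cc(NC(=O)CCCCCNC(=O)CCCc2ccccc2)cc2c1OCC([N+](=O)[O-])=C2`) has not yet been measured. Its change is ((3-phenylpropyl)carbonyl)amino in place of ((2-aminophenyl)carbamoyl)methyl on a saturated chain carbon, five bonds along the chain from a carbonyl carbon.

Going by the values given here, only one measured step offers any guidance. The step of a 2.0-fold lower number from compound 1 to compound 2 (0.30 log units; within the scatter) comes from 5-methylthiophen-2-yl in place of hydrogen on an aromatic carbon. That step stays within the scatter, but it keeps the ((2-aminophenyl)carbamoyl)methyl group that compound 3 loses. Among the compounds with values here, no measured compound shows what losing this group does, so the guidance is weak. The expected change is therefore small, with a slightly higher number and nothing clearly beyond the scatter: the estimate is a 1.2-fold higher number from compound 1 to compound 3 (0.08 log units; within the scatter). For compound 3 the expected value is 14000 nM, with an estimated range from 5000 nM to 40000 nM.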

Compound 3, concentration for 50% growth inhibition: 5230 nM
Compound 3: the middle estimate sits 2.7-fold (0.43 log units) above what was measured; low and high end bracket the measured number.
By their numbers in this assay, from the lowest: compounds 3, 2 and 1 (each within the scatter of the next, the first and the last beyond it).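

Putting ((3-phenylpropyl)carbonyl)amino in place of ((2-aminophenyl)carbamoyl)methyl on a saturated chain carbon, five bonds along the chain from a carbonyl carbon, gives a 2.2-fold lower number from compound 1 to compound 3 (0.35 log units; beyond the scatter) in this assay. The earlier step kept the ((2-aminophenyl)carbamoyl)methyl group and changed only a hydrogen on an aromatic carbon, whereas this step replaces the whole group and shows that growth inhibition in these cells does not depend on that group being present. No measurement here accounts for the lower number, so the step stands as an observation without an explanation.

The entering group differs from the leaving group in several features at once, including the order of its chain and amide parts and its counts of hydrogen-bond donors and acceptors, so the compounds shown cannot say which feature goes with the lower number. A simple amine or a carboxylic acid on the same chain carbon, or a longer chain ending in the same phenyl ring, would help to separate the contribution of the ring from that of the chain.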